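A few compounds are considered here, and "the series" means these few. Any claim that something is new, unique, unknown or untested is made for them only; others in the source may bear on it.

Measured compounds:
- compound 1, `COc1ncnc2c1c(-c1ccsc1)cn2[C@@H]1O[C@H](CO)[C@@H](O)[C@H]1O`: 140 nM
- compound 2, `CN(C)c1ncnc2c1c(-c1ccsc1)cn2[C@@H]1O[C@H](CO)[C@@H](O)[C@H]1O`: a limit, > 20000 nM
- compound 3, `COc1ncnc2c1c(-c1ccoc1)cn2[C@@H]1O[C@H](CO)[C@@H](O)[C@H]1O`: 130 nM

In a functional assay on HCT-116 cells (Homo sapiens), read by MTT assay, with a stated time of 72 h (on this read-out higher numbers stand for weaker inhibition and lower numbers for stronger inhibition), compound 1 gives 140 nM. Compound 2 reaches only a limit of the assay, > 20000 nM, so no number is known for it. Compound 3 gives 130 nM.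

The change from compound 1 to compound 2 is dimethylamino in place of methoxy on an aromatic carbon. It made a large step, an at least 140-fold higher number from compound 1 to compound 2 (2.15 log units; beyond the scatter); the size of that step is bounded by the limit of > 20000 nM in this assay, at which 1 of the 3 values shown sits, which is why only a lower bound on it can be given.

Compound 1 and compound 3 differ in their cores by furan-3-yl in place of thiophen-3-yl on an aromatic carbon. This gave a 1.1-fold lower number from compound 1 to compound 3 (0.03 log units; within the scatter), so the two cores behave alike in this assay.

Compound 4, `CN(C)c1ncnc2c1c(-c1ccoc1)cn2[C@@H]1O[C@H](CO)[C@@H](O)[C@H]1O`, has not yet been measured. It differs from compound 3 by dimethylamino in place of methoxy on an aromatic carbon. The place of the change in compound 4 is the same, word for word, as the place of the change from compound 1 to compound 2, so this is the same change made on the other core. Since the two cores gave values within the scatter of each other, the step from compound 3 to compound 4 is expected to resemble the step from compound 1 to compound 2, that is a 230-fold higher number from compound 3 to compound 4 (2.36 log units; beyond the scatter). Compound 4 is therefore estimated at 30000 nM, most probably reported as a limit again, with a plausible range from 8000 nM to 100000 nM.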

Compound 4, half-maximal inhibitory concentration: > 20000 nM
Compound 4: a limit, no number; the forecaster's own chance of this, stated with the estimate: 80%; the middle value does not contradict the limit.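

In this assay, dimethylamino in place of methoxy on an aromatic carbon again gave a large step on the core of compound 3, which carries furan-3-yl: an at least 150-fold higher number from compound 3 to compound 4 (2.18 log units; beyond the scatter). The change therefore carried across both cores shown, with each step beyond the scatter and pointing the same way, and the two can be set side by side: the same change on two cores in this assay, an at least 140-fold higher number (2.15 log units; beyond the scatter) from compound 1 to compound 2 and an at least 150-fold higher number (2.18 log units; beyond the scatter) from compound 3 to compound 4; the limit leaves it open whether they differ What this does not show is whether the change costs the same on both cores, and the step between compound 2 and compound 4 cannot be read, because each step is only a lower bound set by the assay limit: the limit of > 20000 nM in this assay, at which 2 of the 4 values shown sit.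

The compounds shown leave open whether an unsubstituted amino group, a methylamino group or a longer alkoxy chain such as ethoxy, in place of methoxy, would stay close to the methoxy compounds or would fall to the same limit as dimethylamino. They also leave open whether the same change would behave alike with a phenyl ring or another six-membered aromatic ring in place of thiophen-3-yl or furan-3-yl.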